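A few compounds are considered here, and "the series" means these few. Any claim that something is new, unique, unknown or untested is made for them only; others in the source may bear on it.

Series notes. Compound 1 `CCOc1ccccc1OCCSC(=S)N[C@H]1CCOC1=O`, compound 2 `CC(C)(C)c1ccc(/C=C/C(=O)c2ccc(OCC(=O)N[C@H]3CCOC3=O)cc2)cc1` and compound 3 `O=C(CNc1ccc(Cl)cc1Cl)N[C@H]1CCOC1=O` share one core and were all tested in a functional assay on MCF7 cells (Homo sapiens) for antiproliferative activity, read by MTT assay, with a stated time of 72 h; on this read-out lower numbers stand for stronger inhibition and higher numbers for weaker inhibition. In this assay, going by the values given here, compound 2 gives 16400 nM, the only value in the set that is a number. Compound 1 gives only a limit, > 64000 nM. Compound 3 likewise gives only a limit, > 64000 nM. That is the limit of > 64000 nM in this assay, at which 2 of the 3 values shown sit. Compound 2 therefore stands as the single measurable point in this assay, with nothing above or below it to rank against.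

Compound 4 `O=C(COc1ccc(C(=O)/C=C/c2ccc(Br)cc2)cc1)N[C@H]1CCOC1=O` has not yet been measured. It differs from compound 2 by bromo in place of tert-butyl on an aromatic carbon. Among the compounds with values here, no measured pair in this set differs in one place, so no measured step exists to set the size of this change against, and the starting value of compound 2 in this assay is 16400 nM. The expected step is a 1.2-fold higher number from compound 2 to compound 4 (0.09 log units; within the scatter), not beyond the usual scatter in either direction. Compound 4 is accordingly estimated to give 20000 nM in this assay, with a range from 7000 nM to 60000 nM, and some chance that only a limit is returned.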

Compound 4, half-maximal inhibitory concentration: > 64000 nM
Compound 4 was reported as a limit; the forecaster's own chance of this, stated with the estimate: 25%; middle value at least 3.2-fold (0.50 log units) from the limit.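

Bromo in place of tert-butyl, on an aromatic carbon para to a large group, gives an at least 3.9-fold higher number from compound 2 to compound 4 (0.59 log units; beyond the scatter) in this assay, the only readable step in the series so far and one that shows this position is not indifferent to the change. Going by these compounds alone, compound 4 gives > 64000 nM, which is a limit and not a number, so compound 2 remains the only compound with a measurable value. The full size of the step cannot be read because its upper end is cut off by the assay limit: the limit of > 64000 nM in this assay, at which 3 of the 4 values shown sit.

A single pair cannot separate the loss of tert-butyl from the entry of bromo. Going by these compounds, it remains open how a hydrogen, a methoxy group, a trifluoromethyl group or a longer alkyl chain at this position would compare with compound 2.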